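The source may hold more compounds than are shown below. What is called first, only, known or untested is meant among the compounds shown, and "the series" means these compounds.

The study concerns a set of compounds built on the shared core of compound 1 `O=C(Nc1ccc(Oc2ccnc3[nH]ccc23)cc1)c1nn(-c2ccc(Br)cc2)ccc1=O`, each tested in a functional assay on A549 cells (Homo sapiens) for cytotoxicity, read by MTT assay, with a stated time of 72 h; on this read-out higher numbers stand for weaker inhibition and lower numbers for stronger inhibition. In this assay compound 1 gives 6240 nM. Compound 2 `O=C(Nc1ccc(Oc2ccnc3[nH]ccc23)c(F)c1)c1nn(-c2ccc(Cl)cc2)ccc1=O` adds fluoro and bears chloro in place of bromo; in this assay compound 2 reaches only the limit of > 60000 nM. Compound 3 `COc1ccc(-n2ccc(=O)c(C(=O)Nc3ccc(Oc4ccnc5[nH]ccc45)c(F)c3)n2)cc1` carries methoxy where compound 2 carries chloro, and in this assay compound 3 likewise reaches only the limit of > 60000 nM. The step that the two limits leave unreadable from compound 2 to compound 3 therefore cannot be read, as the limit of > 60000 nM in this assay, at which 2 of the 3 values shown sit, shows. Compound 4 `O=C(Nc1ccc(Oc2ccnc3[nH]ccc23)c(F)c1)c1nn(-c2ccc(Br)cc2)ccc1=O` differs from compound 3 by bromo in place of methoxy on an aromatic carbon. Among the measured compounds shown here, no measured step bears directly on this change: the pair of compound 2 and compound 3 leaves its size unreadable, and compound 1 differs from compound 4 in a further place. Compound 1 stands well away from the limit, while compound 2, which shares the fluoro of compound 4, sits at it. Compound 4 is expected to show a step of an at least 1.5-fold lower number from compound 3 to compound 4 (0.17 log units; that floor lies within the scatter) in this assay, which means no change that can be read. Compound 4 is estimated at 40000 nM, with a range from 10000 nM to 200000 nM, and a fair chance that only a limit is reported.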

Compound 4, half-maximal inhibitory concentration: > 60000 nM
Compound 4: a limit, no number; the forecaster's own chance of this, stated with the estimate: 55%; middle value at least 1.5-fold (0.17 log units) away from the limit.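

In this assay, fluoro in place of hydrogen on an aromatic carbon, with the 4-bromophenyl group kept, gives an at least 9.6-fold higher number from compound 1 to compound 4 (0.98 log units; beyond the scatter), the only step among these compounds that can be read. Among the earlier compounds, this change stood mixed with a second difference, chloro or methoxy in place of bromo, whereas here it stands alone and the weaker read-out goes with the fluoro compound. The steps among the three fluoro compounds, including bromo in place of methoxy and bromo in place of chloro, cannot be read, because each of these compounds gives only a limit and no number: the limit of > 60000 nM in this assay, at which 3 of the 4 values shown sit.

From the compounds shown here alone, the full size of the step to compound 4 stays open, as does whether bromo, chloro and methoxy differ at all on the aromatic ring once the fluoro is absent. Also open, going by these compounds, is how an amine or a carboxylic acid would read in this assay on an aromatic carbon of that six-membered ring, para to a large group, with or without the fluoro.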